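Swapping the aryl group on a thiosemicarbazone hydrazone

A few compounds are considered here, and "the series" means these few. Any claim that something is new, unique, unknown or untested is made for them only; others in the source may bear on it.

Two compounds share a thiosemicarbazide core. Compound 1 `CC1=CC[C@H](C(C)(C)NC(=S)NN)CC1` carries a free terminal nitrogen; in a functional assay on MCF7 cells (Homo sapiens) for inhibition, read by sulforhodamine B assay, with a stated time of 48 h (on this read-out higher numbers stand for weaker inhibition of growth and lower numbers for stronger inhibition of growth), compound 1 gives 46700 nM. Compound 2 `CC1=CC[C@H](C(C)(C)NC(=S)N/N=C/c2ccccc2Cl)CC1` adds a 2-chlorophenyl hydrazone and in this assay gives 98300 nM, the higher of the two numbers and beyond the scatter of compound 1. Compound 3 `CC1=CC[C@H](C(C)(C)NC(=S)N/N=C/c2cccs2)CC1` differs from compound 2 by thiophen-2-yl in place of 2-chlorophenyl on a carbon with a double bond to nitrogen. Within the data shown here, no measured step guides this change, so only a small step in this assay is expected, a 1.2-fold lower number from compound 2 to compound 3 (0.09 log units; within the scatter), within the usual scatter. Compound 3 is estimated at 80000 nM, ranging from 30000 nM to 200000 nM.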

Compound 3, concentration for total growth inhibition: 11500 nM
Compound 3: middle estimate off by 7.0-fold (0.84 log units), on the high side, and the stated range ends above it.
By their numbers in this assay, from the lowest: compound 3; then compound 1; then compound 2.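

In this assay, the group on this carbon with a double bond to nitrogen clearly matters: thiophen-2-yl in place of 2-chlorophenyl gives an 8.5-fold lower number from compound 2 to compound 3 (0.93 log units; beyond the scatter) on the same core. Building on the free terminal nitrogen can also go the other way from compound 2, with a 4.1-fold lower number from compound 1 to compound 3 (0.61 log units; beyond the scatter) in favour of stronger growth inhibition. No measurement here accounts for either step.

Still open, going by these compounds, is whether the ring swap itself or the loss of chlorine carries the step. A plain phenyl or a furan-2-yl group on the same carbon would help separate the two.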